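This account rests on a few compounds, and the source may have more. Where it says the series, first, only, none or still open, it means among the compounds named here.

Three compounds were measured in an ADME assay on MCF7 cells (Homo sapiens) for cytotoxicity, read by MTT assay, with a stated time of 48 h; a higher number here means a weaker inhibitor, a lower number a stronger inhibitor:

Compound 1, `COc1ccc(-c2[nH]c3cc(F)ccc3c2Cn2ccnc2)cc1`: > 1000000 nM
Compound 2, `COc1ccc(-c2[nH]c3cc(Cl)ccc3c2Cn2ccnc2)cc1`: > 1000000 nM
Compound 3, `Fc1ccc(-c2[nH]c3cc(Cl)ccc3c2Cn2cncn2)cc1`: 625000 nM

In this assay compound 1 reaches only a limit of the assay, > 1000000 nM, not a number. Compound 2 likewise reaches only a limit, > 1000000 nM. For the measured compounds named here, compound 3 is the one compound with a real number, 625000 nM in this assay.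

Compound 1 and compound 2 differ in one place: chloro in place of fluoro on an aromatic carbon. The size of that step, a step that the two limits leave unreadable from compound 1 to compound 2, cannot be read because of the limit of > 1000000 nM in this assay, at which 2 of the 3 values shown sit. The difference between the core of compound 1 and the core of compound 3 is not broken down here.

Compound 4, `Clc1ccc(-c2[nH]c3cc(Cl)ccc3c2Cn2cncn2)cc1`, has not been measured. It differs from compound 3 by chloro in place of fluoro on an aromatic carbon. Going by the values given here, this is the same kind of change as the one from compound 1 to compound 2, but not the same: there the place was on an aromatic carbon of a six-membered ring that is part of a fused system of two rings, meta to a fused ring and para to a fused ring; here it is on a six-membered aromatic ring of carbon only, para to a large group.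

The step from compound 3 to compound 4 is expected to be small, a 1.3-fold lower number from compound 3 to compound 4 (0.10 log units; within the scatter), resting on compound 3 at 625000 nM as the only readable anchor, since the earlier step of this kind gave no readable size. Compound 4 is therefore estimated at 500000 nM, most likely between 150000 nM and 1500000 nM.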

Compound 4, half-maximal inhibitory concentration: 382000 nM
Compound 4: middle estimate off by 1.3-fold (0.12 log units), on the high side, and the stated range covers the measured number.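

In this assay, replacing fluoro with chloro, which turns the 4-fluorophenyl group into a 4-chlorophenyl group, gives a 1.6-fold lower number from compound 3 to compound 4 (0.21 log units; within the scatter), so on this core the change makes no difference that can be told apart from ordinary variation between repeated measurements. The same kind of change in a different place, on the core of compound 1, gives no size to set beside it, because the values of both compound 1 and compound 2 are limits of the assay and not numbers: the limit of > 1000000 nM in this assay, at which 2 of the 4 values shown sit. This leaves a single readable step of this kind, so it shows what the change does on the core of compound 3 but does not show whether that result carries over from one core to another in this series.

On these data alone, it remains open whether a different group, such as an amine or a carboxylic acid, in place of the chloro of compound 4 would move the number by more than the usual scatter. Also open is how each separate difference between the core of compound 1 and the core of compound 3 contributes, since no pair shown changes just one of them.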